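A Methyl Group on the Aromatic Nitrogen of Compound 1

The source may report more compounds than this note shows. Statements on the series, on what has been measured and on what is new or still open speak of the compounds shown alone.

Compound 1, `COc1cc(-n2cncc2-c2ccc3[nH]ccc3c2)cc(OC)c1OC`: 540 nM
Compound 2, `COc1ccc(-c2ccnn2-c2cc(OC)c(OC)c(OC)c2)cc1N`: 33 nM

In a functional assay on NCI-H460 cells (Homo sapiens) for inhibition (a lower number here means a stronger inhibitor, a higher number a weaker inhibitor), compound 1 gives 540 nM, the highest of the two numbers shown, while compound 2 gives 33 nM, a gap beyond the scatter. Among the compounds with values here, the two compounds differ in more than one place, so their values show only that compound 1 is the weaker of the pair. Compound 3, `COc1cc(-n2cncc2-c2ccc3c(ccn3C)c2)cc(OC)c1OC`, differs from compound 1 by methyl in place of hydrogen on an aromatic nitrogen. Within the data shown here, no measured pair shows this change, so the step from compound 1 to compound 3 is expected to be small, a 1.3-fold higher number from compound 1 to compound 3 (0.11 log units; within the scatter), within the scatter. Compound 3 is therefore estimated at 700 nM, with a range from 250 nM to 2000 nM.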

Compound 3, half-maximal inhibitory concentration: 19 nM
The estimate for compound 3 lay 37-fold (1.57 log units) above the measured number; the whole stated range lies above it.
By their numbers in this assay, from the lowest: compounds 3 and 2 (each within the scatter of the next); then compound 1.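

In this assay, methyl in place of hydrogen on the aromatic nitrogen gives a 28-fold lower number from compound 1 to compound 3 (1.45 log units; beyond the scatter) and so shows that this position responds strongly to the addition of a single carbon. The earlier compounds shown here could not show this, as compound 1 and compound 2 differ in more than one place. Nothing available here accounts for the size of this step. Methyl is the only group seen on this nitrogen. As far as these compounds go, whether an ethyl group, a longer chain or a chain ending in an amine would give a similar number remains open.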